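The source may report more compounds than this note shows. Statements on the series, on what has been measured and on what is new or still open speak of the compounds shown alone.

Measured in a functional assay on HeLa cells (Homo sapiens) for cytotoxicity, read by MTT assay; on this read-out lower numbers stand for stronger inhibition and higher numbers for weaker inhibition:
Compound 1 `CC(C)=CC[C@@H](OC[C@H](C)O)C1=CC(=O)c2c(O)ccc(O)c2C1=O`: 40300 nM
Compound 2 `CCCC(O)CC(=O)O[C@H](CC=C(C)C)C1=CC(=O)c2c(O)ccc(O)c2C1=O`: 59300 nM
Compound 3 `CC(=O)OCCO[C@H](CC=C(C)C)C1=CC(=O)c2c(O)ccc(O)c2C1=O`: 41500 nM

These three compounds share a core and differ in the group on an oxygen on a saturated carbon. Compound 2 cannot be told apart from the other two in this assay. The data show a 1.5-fold higher number from compound 1 to compound 2 (0.17 log units; within the scatter), and also a 1.4-fold lower number from compound 2 to compound 3 (0.16 log units; within the scatter).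

Compound 4 `COCCO[C@H](CC=C(C)C)C1=CC(=O)c2c(O)ccc(O)c2C1=O` has not yet been measured. It differs from compound 2 by one change: 2-methoxyethyl in place of (2-hydroxypentyl)carbonyl on an oxygen on a saturated carbon. In words, this is 2-methoxyethyl in place of (2-hydroxypentyl)carbonyl on an oxygen on a saturated carbon.

The closest guide is compound 3, which carries 2-acetoxyethyl at that same place, and the change to it gave a 1.4-fold lower number from compound 2 to compound 3 (0.16 log units; within the scatter). The remaining step among the measured compounds is a 1.0-fold higher number from compound 1 to compound 3 (0.01 log units; within the scatter). For the measured compounds named here, no measured compound carries 2-methoxyethyl itself, so this remains an inference from neighbouring groups. All three measured steps stayed small, so no change beyond the scatter is expected here.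

The expected change is a 1.4-fold lower number from compound 2 to compound 4 (0.15 log units; within the scatter), which would leave compound 4 level with the others. For compound 4 the estimated value is 42000 nM, with an expected range from 20000 nM to 85000 nM.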

Compound 4, half-maximal inhibitory concentration: 62400 nM
For compound 4 the middle estimate is 1.5-fold (0.17 log units) below the measured one; low and high end bracket the measured number.
By their numbers in this assay, from the lowest: compounds 1, 3, 2 and 4 (each within the scatter of the next).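

In this assay the swap of (2-hydroxypentyl)carbonyl for 2-methoxyethyl on this oxygen gives a 1.1-fold higher number from compound 2 to compound 4 (0.02 log units; within the scatter) even though the entering group has 4 heavy atoms against 8 and 0 hydrogen-bond donors against 1, so the read-out does not separate these two groups. Methyl in place of acetyl on an oxygen gives a 1.5-fold higher number from compound 3 to compound 4 (0.18 log units; within the scatter) and methoxymethyl in place of 1-hydroxyethyl gives a 1.5-fold higher number from compound 1 to compound 4 (0.19 log units; within the scatter) in the same way, which extends the flat picture to a fourth compound: all four groups on this oxygen read alike, and none can be ranked above another. The data shown offer no measurement that accounts for this flatness.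

From the compounds shown here alone, all four groups are open chains carrying oxygen, so it remains open whether an amine or a carboxylic acid at the end of the chain would move the number beyond the scatter. The same question stands for a much longer carbon chain or a phenyl ring on this oxygen.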